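Working notes on compounds 1 to 4

This account rests on a few compounds, and the source may have more. Where it says the series, first, only, none or still open, it means among the compounds named here.

Measured in an assay for inhibition of MAP kinase-interacting serine/threonine-protein kinase 2 (Homo sapiens), read by luminescence and ADP-Glo, with a stated time of 2 h; on this read-out higher numbers stand for weaker inhibition and lower numbers for stronger inhibition:
compound 1 `Nc1cccc(Cn2cc(-c3ccc4cn[nH]c4c3)ccc2=O)c1` gives 84 nM
compound 2 `O=c1ccc(-c2ccc3cn[nH]c3c2)cn1Cc1ccccc1` gives 75 nM
compound 3 `NC(=O)c1ccccc1Cn1cc(-c2ccc3cn[nH]c3c2)ccc1=O` gives 340 nM

Compound 2 holds the lowest of the three numbers in this assay. The nearest is compound 1: a 1.1-fold lower number from compound 1 to compound 2 (0.05 log units; within the scatter), so no order between compound 1 and compound 2 can be read from these two values. The furthest is compound 3: a 4.5-fold higher number from compound 2 to compound 3 (0.66 log units; beyond the scatter).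

Compound 4 `O=c1ccc(-c2ccc3cn[nH]c3c2)cn1Cc1ccc(C(F)(F)F)cc1` differs from compound 2 by trifluoromethyl in place of hydrogen on an aromatic carbon. Among the measured compounds shown here, no measured pair makes this same change. The two steps that bear on it both alter a substituent on the same six-membered aromatic ring of carbon only: a 1.1-fold lower number from compound 1 to compound 2 (0.05 log units; within the scatter), a removal that left the number unchanged, and a 4.5-fold higher number from compound 2 to compound 3 (0.66 log units; beyond the scatter), an addition that raised the number modestly. Neither step places a trifluoromethyl group, and neither sits at the place that compound 4 changes, so their bearing is indirect. The expected step is therefore small, a 1.3-fold higher number from compound 2 to compound 4 (0.12 log units; within the scatter), with a slight lean toward a higher number in line with the one addition on record, compound 3, a 4.5-fold higher number from compound 2 to compound 3 (0.66 log units; beyond the scatter). Compound 4 is estimated at 100 nM, with a range of 40 nM to 300 nM.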

Compound 4, half-maximal inhibitory concentration: 1110 nM
Beside the measured number, compound 4's estimate is 11-fold (1.05 log units) below it; the whole stated range lies below it.
By their numbers in this assay, from the lowest: compounds 2 and 1 (each within the scatter of the next); then compound 3; then compound 4.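

In this assay, among the compounds shown here, trifluoromethyl para to a large group on the six-membered aromatic ring of carbon only gives a 15-fold higher number from compound 2 to compound 4 (1.17 log units; beyond the scatter), so this place on the ring is not indifferent to substitution, and the change is the first on this ring to be printed as large. The earlier steps shown here on this ring were smaller: a 1.1-fold lower number from compound 1 to compound 2 (0.05 log units; within the scatter) and a 4.5-fold higher number from compound 2 to compound 3 (0.66 log units; beyond the scatter), the latter modest. Both groups added to compound 2 in compound 3 and compound 4 go with a higher number, but the amino group of compound 1 goes against any general rule, since that compound stays within the scatter of compound 2, and no measurement at hand gives a reason for the size of the new step.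

As far as these compounds go, whether the rise belongs to trifluoromethyl itself or to any group at this place remains open, and a methyl group, a fluorine atom or a carboxylic acid at the same place would help to separate the two. Also open, from the compounds shown here alone, is whether trifluoromethyl at another place on this ring would raise the number as far.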